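The compounds below may be only part of what the source reports. "The series", "measured", "known", "first", "only" and "open" are said of these compounds alone.

Measured so far in a functional assay on MCF7 cells (Homo sapiens) for cytotoxicity, read by sulforhodamine B assay, with a stated time of 48 h, tested at 0.1 uM; a higher number here means a weaker effect of the compound at the concentration tested, a lower number a stronger effect:
compound 1 `COc1cc(-c2cc(/C=C/C(=O)c3ccc(Cl)c(Cl)c3)[nH]n2)cc(OC)c1OC` gives 105%
compound 2 `COc1ccc(C(=O)/C=C/c2cc(-c3cc(OC)c(OC)c(OC)c3)n[nH]2)cc1OC` gives 91%

Compound 2 stands lowest of the two numbers; its nearest neighbour is compound 1, the two separated by a number 14 percentage points lower from compound 1 to compound 2 (beyond the scatter). Compound 3 `COc1ccc(C(=O)/C=C/c2cc(-c3cc(OC)c(OC)c(OC)c3)n[nH]2)cc1` differs from compound 2 by hydrogen in place of methoxy on an aromatic carbon. Among the compounds with values here, the single measured step, 3,4-dimethoxyphenyl in place of 3,4-dichlorophenyl on a carbonyl carbon, is a different kind of change and gives little guidance for removing one methoxy. For compound 3 the step is expected as a number 4 percentage points higher from compound 2 to compound 3 (within the scatter), not beyond the scatter. The estimate for compound 3 in this assay is 95%, in the range 80% to 110%.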

Compound 3, a percentage reported as activity, at one concentration (the size of the read-out at that concentration, not a potency): 93%
Compound 3: the middle estimate sits 2 percentage points above what was measured; the range from low to high includes it.
By their numbers in this assay, from the lowest: compounds 2 and 3 (each within the scatter of the next); then compound 1.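

In this assay, the change from 3,4-dimethoxyphenyl to 4-methoxyphenyl gives a number 2 percentage points higher from compound 2 to compound 3 (within the scatter), so the methoxy ortho to a methoxy group can be replaced by hydrogen with no readable shift at this concentration. The single remaining methoxy still leaves a separation from the 3,4-dichlorophenyl compound, with a number 12 percentage points lower from compound 1 to compound 3 (beyond the scatter). No available data bear on why this position tolerates the change.

From the compounds shown here alone, it remains open whether the remaining methoxy could give way to a hydroxyl or an amine with the same outcome. Going by these compounds, it is also open whether these steps would hold at other concentrations.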